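This account rests on a few compounds, and the source may have more. Where it says the series, first, only, none or still open, it means among the compounds named here.

Working notes on the series around compound 2.

Compound 2 `CC1(C)C=C(n2ccccc2=O)c2cc(S(=O)(=O)NCCO)ccc2O1` sits highest of the three measured entries in a functional assay on the whole organism (aorta) with Rattus norvegicus as the target; on this read-out higher numbers stand for larger maximal responses and lower numbers for smaller maximal responses: compound 2 reaches 95.5%. Compound 1 `CC1(C)C=C(n2ccccc2=O)c2cc(S(N)(=O)=O)ccc2O1` reaches 77.5% in this assay, and compound 3 `CN(c1ccccc1)S(=O)(=O)c1ccc2c(c1)C(n1ccccc1=O)=CC(C)(C)O2` reaches 64.2% in this assay. The two measured steps that end or start at compound 2 both lie beyond the scatter: a number 18 percentage points higher from compound 1 to compound 2 (beyond the scatter), and a number 31.3 percentage points lower from compound 2 to compound 3 (beyond the scatter). The third step, a number 13.3 percentage points lower from compound 1 to compound 3 (beyond the scatter), is modest.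

Compound 4 `CC1(C)C=C(n2ccccc2=O)c2cc(S(=O)(=O)Oc3ccccc3)ccc2O1` is not yet measured in this assay. It differs from compound 2 in one place: phenoxy in place of (2-hydroxyethyl)amino on a sulfonyl sulfur. For the measured compounds named here, the measured step that bears most directly on this change is the one from compound 2 to compound 3, where a group with the same two hydrogen-bond donors left and a group carrying a phenyl with none entered, with a large fall. The step from compound 1 to compound 2 shows that adding the 2-hydroxyethyl group raised the response modestly. For compound 4 the expected step is therefore downward and beyond the scatter, a number 29.5 percentage points lower from compound 2 to compound 4 (beyond the scatter), because compound 3 gives 64.2% after a comparable loss of the donors. Compound 4 is expected to reach about 66% in this assay, within a range from 50% to 82%.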

Compound 4, largest response reached (Emax), in percent of the reference or control that the assay uses: 67.9%
Compound 4: middle estimate off by 1.9 percentage points, on the low side, within the range that was stated.
By their numbers in this assay, from the lowest: compounds 3, 4 and 1 (each within the scatter of the next, the first and the last beyond it); then compound 2.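

In this assay, the fall from compound 2 does not depend on a nitrogen staying on the sulfonyl sulfur: phenoxy, with an oxygen there and 0 hydrogen-bond donors, also gives a clear drop (a number 27.6 percentage points lower from compound 2 to compound 4 (beyond the scatter)). Phenoxy cannot be separated from methyl(phenyl)amino (a number 3.7 percentage points higher from compound 3 to compound 4 (within the scatter)) or from the plain amino group (a number 9.6 percentage points lower from compound 1 to compound 4 (within the scatter)), so among the four compounds only the (2-hydroxyethyl)amino group of compound 2 stands apart, while compound 1, which lacks any added aromatic ring, does not share its high response. No measurement is available that explains these differences.

The compounds shown leave open whether the response of compound 2 goes with the hydroxyl or with the ethyl chain that carries it, a question that 2-methoxyethyl or plain ethyl on the sulfonamide nitrogen would address. Going by these compounds, it also remains open how a longer chain such as 3-hydroxypropyl, or a chain ending in an amine or a carboxylic acid, would compare with the 2-hydroxyethyl group on this sulfonyl sulfur.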